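The source may hold more compounds than are shown below. What is called first, only, known or untested is meant among the compounds shown, and "the series" means these compounds.

Measured so far in an assay for inhibition of Polyunsaturated fatty acid lipoxygenase ALOX15 (Oryctolagus cuniculus), read by spectrophotometry; a higher number here means a weaker inhibitor, a lower number a stronger inhibitor: compound 1 `COc1ccc(-c2cc3ccccc3[nH]2)cc1NS(=O)(=O)NC(=O)OCC(C)C` gives 1450 nM; compound 2 `COc1ccc(-c2cc3cc(F)ccc3[nH]2)cc1NS(=O)(=O)NC(=O)OCC(C)C` gives 420 nM; compound 3 `C=CCOC(=O)NS(=O)(=O)Nc1cccc(-c2cc3ccccc3[nH]2)c1` gives 15400 nM.

Compound 2 stands lowest of the three numbers in this assay. Its nearest neighbour is compound 1, separated by a 3.5-fold lower number from compound 1 to compound 2 (0.54 log units; beyond the scatter), a step beyond the scatter; compound 3 lies furthest away.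

Compound 4 `C=CCOC(=O)NS(=O)(=O)Nc1cc(-c2cc3cc(F)ccc3[nH]2)ccc1OC` differs from compound 2 by vinyl in place of isopropyl on a saturated chain carbon bound to an oxygen next to a carbonyl group. Among the compounds with values here, no measured step isolates this change. Compound 3 carries the allyloxycarbonyl group and gives 15400 nM, while compound 1 with the isobutoxycarbonyl group gives 1450 nM, but compound 3 and compound 1 differ in more than one place, so the carbamate change alone is not separated from the rest. Within the data shown here, the only clean step, a 3.5-fold lower number from compound 1 to compound 2 (0.54 log units; beyond the scatter), concerns the fluoro substitution and does not bear on the carbamate.

With the fluoro kept in compound 4, a weakening that stays near or just beyond the scatter is expected, giving a 2.1-fold higher number from compound 2 to compound 4 (0.33 log units; beyond the scatter). The estimate for compound 4 in this assay is 900 nM, with a range from 300 nM to 3000 nM.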

Compound 4, half-maximal inhibitory concentration: 540 nM
Beside the measured number, compound 4's estimate is 1.7-fold (0.22 log units) above it, and the stated range covers the measured number.
By their numbers in this assay, from the lowest: compounds 2 and 4 (each within the scatter of the next); then compound 1; then compound 3.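

In this assay, the change from isobutoxycarbonyl to allyloxycarbonyl, with the rest of the molecule held fixed, gives a 1.3-fold higher number from compound 2 to compound 4 (0.11 log units; within the scatter), so at this position vinyl in place of isopropyl leaves the number within the scatter. The earlier compounds shown here could not show this, since compound 1 and compound 3 differ in more than one place and no earlier step isolated the carbamate chain. No measurement at hand offers a reason for this result.

The compounds shown leave open whether this position would accept a group of a different kind, such as a longer chain, a benzyl group or a terminal amine. They also leave open whether the same change would give a similar step on the core of compound 1, which lacks the fluoro.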